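The source may hold more compounds than are shown below. What is called first, only, known or untested is meant among the compounds shown, and "the series" means these compounds.

Among the compounds with values here, compound 1 `Cc1ccc(Cn2ccnc2NC(=O)[C@@H]2CN(C(C)(C)C)C[C@H]2c2ccc(F)cc2F)c(N2CCC(C(=O)O)CC2)c1` is the only compound here with a number: in a functional assay for agonist activity at Melanocyte-stimulating hormone receptor (Homo sapiens), read by cAMP accumulation (a lower number here means that less compound is needed, a higher number that more compound is needed for the effect), compound 1 gives 318 nM. Compound 2 `CC(C)(C)N1C[C@@H](C(=O)Nc2nccn2Cc2ccc(Cl)cc2)[C@H](c2ccc(F)cc2F)C1` reaches only a limit of this assay, at > 10000 nM (the limit of > 10000 nM in this assay, at which 1 of the 2 values shown sits). Compound 3 `CC(C)(C)N1C[C@@H](C(=O)Nc2nccn2Cc2ccccc2N2CCC(C(=O)O)CC2)[C@H](c2ccc(F)cc2F)C1` differs from compound 1 by hydrogen in place of methyl on an aromatic carbon. Within the data shown here, no measured pair shows the effect of this change, so the step from compound 1 to compound 3 is expected to be small, at most a modest loss beyond the scatter, an expected 1.6-fold higher number from compound 1 to compound 3 (0.20 log units; within the scatter). Compound 3 is therefore estimated at 500 nM, with a range from 150 nM to 2000 nM.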

Compound 3, half-maximal effective concentration: 460 nM
Compound 3: the middle estimate sits 1.1-fold (0.04 log units) above what was measured; low and high end bracket the measured number.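

With hydrogen in place of methyl, meta to the 4-carboxypiperidin-1-yl group, the shared core gives its first measured step at this position: a 1.4-fold higher number from compound 1 to compound 3 (0.16 log units; within the scatter). The methyl on this aromatic carbon is therefore not needed for a measurable value, and the two compounds stay within the scatter of each other. Nothing at hand bears on a cause for this step. As far as these compounds go, it remains open what chlorine, a methoxy group or an amine at this carbon would give, and whether an amide could stand in for the carboxylic acid on the piperidine.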